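The source may report more compounds than this note shows. Statements on the series, on what has been measured and on what is new or still open speak of the compounds shown alone.

Series overview in an ADME assay on L6 cells (Rattus norvegicus) for cytotoxicity, read by resazurin assay, with a stated time of 72 h; on this read-out lower numbers stand for an effect already at smaller amounts and higher numbers for an effect only at larger amounts of compound:

compound 1 `CCOC(=O)C1=C(C)N/C(=C/c2cc(C)n(-c3cccc(C(F)(F)F)c3)c2C)C1=O` — 100000 nM
compound 2 `CCOC(=O)C1=C(C)N/C(=C/c2cc(C)n(-c3ccc(OC)cc3)c2C)C1=O` — 140000 nM
compound 3 `CCOC(=O)C1=C(C)N/C(=C/c2cc(C)n(-c3cccc(OC)c3)c2C)C1=O` — 56000 nM

Compound 3 gives the lowest of the three numbers. Among the compounds with values here, one step, a 1.8-fold lower number from compound 1 to compound 3 (0.25 log units; within the scatter), stays within the scatter; the other step, a 2.5-fold lower number from compound 2 to compound 3 (0.40 log units; beyond the scatter), is the only step in the set that reaches beyond the scatter.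

Compound 4 `CCOC(=O)C1=C(C)N/C(=C/c2cc(C)n(-c3cccnc3)c2C)C1=O` differs from compound 3 in one place: pyridin-3-yl in place of 3-methoxyphenyl on an aromatic nitrogen.

Within the data shown here, two measured steps bear on this change. The swap of the group on the same aryl carbon, a 1.8-fold lower number from compound 1 to compound 3 (0.25 log units; within the scatter), did not move the number beyond the scatter. Moving the methoxy from the 4- to the 3-position, a 2.5-fold lower number from compound 2 to compound 3 (0.40 log units; beyond the scatter), gave a modest change. Among the measured compounds shown here, no measured compound carries a ring nitrogen in the aryl group, so the step to compound 4 has no direct precedent. Given that the only sizeable step in the series is modest, the expected step from compound 3 to compound 4 in this assay is a 1.3-fold higher number from compound 3 to compound 4 (0.10 log units; within the scatter), no larger than the scatter in either direction. Compound 4 is therefore estimated at 70000 nM, expected within 30000 nM to 160000 nM.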

Compound 4, half-maximal effective concentration: 160000 nM
Beside the measured number, compound 4's estimate is 2.3-fold (0.36 log units) below it; measured number inside the range.
By their numbers in this assay, from the lowest: compounds 3, 1, 2 and 4 (each within the scatter of the next, the first and the last beyond it).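

In this assay, pyridin-3-yl on the aromatic nitrogen gives a 2.9-fold higher number from compound 3 to compound 4 (0.46 log units; beyond the scatter) and is, among the groups shown at this position, the only aryl ring with a hetero atom; the step is modest, so that ring nitrogen does not open a wider range of values here. Against the other two aryl groups the change reads differently, with a 1.1-fold higher number from compound 2 to compound 4 (0.06 log units; within the scatter) and a 1.6-fold higher number from compound 1 to compound 4 (0.20 log units; within the scatter) both staying within the scatter, so the two steps beyond the scatter in this set both involve compound 3, although its step from compound 1 does not leave the scatter. Nothing available explains the step from the 3-methoxyphenyl group.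

The compounds shown leave open whether that step follows from the ring nitrogen or from losing the methoxy group. A plain phenyl, pyridin-4-yl or 3-aminophenyl on this nitrogen would separate these readings.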